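Swapping cyano for trifluoromethyl on a second core

A few compounds are considered here, and "the series" means these few. Any claim that something is new, unique, unknown or untested is made for them only; others in the source may bear on it.

Measured compounds:
compound 1, `O=C(Nc1ccc(C(F)(F)F)cc1)c1cc(Cl)ccc1O`, 510 nM
compound 2, `N#Cc1ccc(NC(=O)c2ccc(Cl)cc2O)cc1`, 1300 nM
compound 3, `N#Cc1ccc(NC(=O)c2cc(Cl)ccc2O)cc1`, 700 nM

In a functional assay on HL-60 cells (Homo sapiens) for cytotoxicity, read by luminescence and CellTiter-Glo, with a stated time of 3 days (a lower number here means a stronger inhibitor, a higher number a weaker inhibitor), compound 2 gives the highest of the three numbers, but its gap to compound 3 is within the usual scatter, so no order between those two can be read. Compound 1 and compound 3 share one core and differ only by a change of trifluoromethyl in place of cyano on an aromatic carbon; that change gave a 1.4-fold lower number from compound 3 to compound 1 (0.14 log units; within the scatter), a step too small to count as a real gain.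

Compound 2 and compound 3 are built from the same atoms joined differently; the difference between the two cores is not broken down here. Compound 4, `O=C(Nc1ccc(C(F)(F)F)cc1)c1ccc(Cl)cc1O`, is not yet measured. It stands to compound 2 as compound 1 stands to compound 3: the change is trifluoromethyl in place of cyano on an aromatic carbon, the same change made on the other core.

Because the earlier instance gave a 1.4-fold lower number from compound 3 to compound 1 (0.14 log units; within the scatter), the step from compound 2 to compound 4 is expected to be small as well, estimated as a 1.4-fold lower number from compound 2 to compound 4 (0.14 log units; within the scatter). Compound 4 is therefore estimated at 950 nM, with a likely range of 400 nM to 2200 nM.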

Compound 4, half-maximal inhibitory concentration: 630 nM
Compound 4: the middle estimate sits 1.5-fold (0.18 log units) above what was measured; the range from low to high includes it.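

In this assay, putting trifluoromethyl in place of cyano on this second core gave a 2.1-fold lower number from compound 2 to compound 4 (0.31 log units; beyond the scatter), a modest step. The two cores give steps that cannot be told apart: the same change on two cores in this assay, a 1.4-fold lower number (0.14 log units; within the scatter) from compound 3 to compound 1 and a 2.1-fold lower number (0.31 log units; beyond the scatter) from compound 2 to compound 4, 1.5-fold (0.18 log units) apart, within the scatter of two such steps. The change therefore carried over from one core to the other with a comparable size, but two cores are a small sample, and these numbers neither explain the step nor show that it would hold on a further core.

On these data alone, only cyano and trifluoromethyl appear at this position, so it remains open how other groups on that aromatic carbon, such as an amine, a carboxylic acid or a longer chain, would compare on either core. As far as these compounds go, every number also comes from this assay, so whether the step would look the same in a different kind of measurement is also open.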